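From pentyl to 4-methylphenyl on an aromatic nitrogen

This account rests on a few compounds, and the source may have more. Where it says the series, first, only, none or still open, it means among the compounds named here.

Measured so far in a functional assay on MDA-MB-468 cells (Homo sapiens) for antiproliferative activity, read by MTT assay, with a stated time of 72 h; a higher number here means a weaker inhibitor, a lower number a stronger inhibitor:
- compound 1 `COc1cc(-c2nccn2C(C)C)cc(OC)c1OC`: > 100000 nM, a limit of the assay
- compound 2 `CCCCn1ccnc1-c1cc(OC)c(OC)c(OC)c1`: 44100 nM
- compound 3 `CCCCCn1ccnc1-c1cc(OC)c(OC)c(OC)c1`: 57900 nM

Compound 3 stands level with compound 2, since pentyl in place of butyl gives a 1.3-fold higher number from compound 2 to compound 3 (0.12 log units; within the scatter). Compound 1 gives only a limit, not a true number. Butyl in place of isopropyl gives an at least 2.2-fold lower number from compound 1 to compound 2 (0.35 log units; beyond the scatter), and pentyl in place of isopropyl gives an at least 1.7-fold lower number from compound 1 to compound 3 (0.23 log units; that floor lies within the scatter).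

Compound 4 `COc1cc(-c2nccn2-c2ccc(C)cc2)cc(OC)c1OC` keeps the shared core but carries 4-methylphenyl in place of pentyl on an aromatic nitrogen. All three measured steps change this same substituent, so they are the closest guide. However, each one swaps one open chain for another, and none brings in a ring, so they set the expected size only loosely. The two steps with a true number on both sides or a clear floor are modest, so a modest fall in the number is expected, though a result level with compound 3 would be no surprise. Expected in this assay is a 2.9-fold lower number from compound 3 to compound 4 (0.46 log units; beyond the scatter). For compound 4 the estimated value is 20000 nM, with an expected range from 4000 nM to 90000 nM.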

Compound 4, half-maximal inhibitory concentration: 400 nM
For compound 4 the middle estimate is 50-fold (1.70 log units) above the measured one, and the stated range ends above it.
By their numbers in this assay, from the lowest: compound 4; then compounds 2 and 3 (each within the scatter of the next). At a limit, above all of these: compound 1.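

In this assay, swapping one open chain for another on this aromatic nitrogen gave modest steps at most, whereas 4-methylphenyl gives a 140-fold lower number from compound 3 to compound 4 (2.16 log units; beyond the scatter) and a 110-fold lower number from compound 2 to compound 4 (2.04 log units; beyond the scatter). The position is therefore far more sensitive to the kind of group it carries than the chains alone could show, since this one change brings in a six-membered aromatic ring of carbon only and the number falls far beyond the scatter. The isopropyl value is a limit of the assay and not a true number, so an at least 250-fold lower number from compound 1 to compound 4 (2.39 log units; beyond the scatter) gives only a floor for the size of this change: the limit of > 100000 nM in this assay, at which 1 of the 4 values shown sits.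

The compounds shown leave open whether the gain comes from having a ring at all, from its being aromatic, or from its methyl group, a question that plain phenyl and cyclohexyl on the same nitrogen would help to separate. For the compounds shown here, with compound 4 as the only ring-bearing example, they also leave open how the number would respond to a methoxy group or a chlorine in place of that methyl.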